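The source may report more compounds than this note shows. Statements on the series, on what has been measured and on what is new or still open speak of the compounds shown alone.

Measured so far, in an assay on HEK293F cells for inhibition of cholesterol 24-hydroxylase (Homo sapiens), read by trypan blue exclusion, with stated times of 15 min and 5 h; a lower number here means a stronger inhibitor, a higher number a weaker inhibitor:
compound 1 `O=C(NC1CC1)C1CCN(c2cnccc2-c2ccccn2)CC1` — 160 nM
compound 2 `CN(C)C(=O)C1CCN(c2cnccc2-c2ccccn2)CC1` — 68 nM

Compound 2 stands lowest of these two numbers. For the measured compounds named here, its only neighbour is compound 1, and the change between them lies on the carbonyl carbon: a 2.4-fold lower number from compound 1 to compound 2 (0.37 log units; beyond the scatter). Compound 3 `CN(C)C(=O)C1CCN(c2cnccc2-n2cccn2)CC1` keeps the dimethylamino carbonyl of compound 2 and alters the other end of the molecule instead: 1H-pyrazol-1-yl in place of pyridin-2-yl on an aromatic carbon. Going by the values given here, no measured step touches this position, so nothing seen so far tells how far the number moves when one aromatic ring is swapped for another here. Among the compounds with values here, the one measured step concerned a different part of the structure and was modest, which gives no ground for expecting a large shift in this assay in either direction. Compound 3 is therefore expected to land near compound 2, with an estimated step of a 1.8-fold higher number from compound 2 to compound 3 (0.25 log units; within the scatter). The estimate for compound 3 is 120 nM, ranging from 30 nM to 500 nM.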

Compound 3, half-maximal inhibitory concentration: 48 nM
Estimate against measurement, compound 3: 2.5-fold (0.40 log units) above; the range from low to high includes it.
By their numbers in this assay, from the lowest: compounds 3 and 2 (each within the scatter of the next); then compound 1.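

For the compounds shown here, this is the first measured change at this place, on an aromatic carbon opposite the ring nitrogen. In this assay the swap gives a 1.4-fold lower number from compound 2 to compound 3 (0.15 log units; within the scatter) and so leaves the two compounds indistinguishable. With the dimethylamino carbonyl kept, a five-membered aromatic ring with 2 hetero atoms therefore serves here as well as a six-membered aromatic ring with 1 hetero atom, and nothing available explains why.

The compounds shown leave open whether this place needs an aromatic ring at all, since a plain phenyl, a non-aromatic morpholine or a small methoxy group could each answer a different part of that question. They also leave open whether 1H-pyrazol-1-yl would behave the same way alongside the cyclopropylamino carbonyl of compound 1.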